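Phenyl to 2-fluorophenyl on compound 1

This account rests on a few compounds, and the source may have more. Where it says the series, first, only, none or still open, it means among the compounds named here.

In a toxicity assay on MT4 cells (Homo sapiens) for cytotoxicity, read by MTT assay (on this read-out lower numbers stand for higher toxicity in this test and higher numbers for lower toxicity in this test), compound 1 `Cc1cc(-c2ccccc2)cc(C)c1Oc1cc(N)nc(Nc2ccc(C#N)cc2)n1` gives 25600 nM as the second highest of three numbers. Compound 3 `COc1cc(Oc2cc(N)nc(Nc3ccc(C#N)cc3)n2)ccc1-c1ccc(C#N)cc1` gives 12900 nM and lies within the scatter of compound 1. Compound 2 `Cc1cc(-c2ccc(C#N)c(C#N)c2)ccc1Oc1cc(N)nc(Nc2ccc(C#N)cc2)n1` gives 76700 nM and stands higher than compound 1 by a gap beyond the scatter. These three compounds differ from one another in more than one place, so they show no measured effect of a single change.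

Compound 4 `Cc1cc(-c2ccccc2F)cc(C)c1Oc1cc(N)nc(Nc2ccc(C#N)cc2)n1` differs from compound 1 in one place (fluoro in place of hydrogen on an aromatic carbon): fluoro in place of hydrogen on an aromatic carbon, ortho to a large group, which turns phenyl into 2-fluorophenyl. With no closer measured comparison, the expectation rests on compound 1 at 25600 nM as the anchor. In this assay no step beyond the scatter is expected, and no direction is favoured. The estimated step of a 1.0-fold lower number from compound 1 to compound 4 (0.01 log units; within the scatter) is expected to be small. Compound 4 is expected at 25000 nM (estimated range 10000 nM to 60000 nM).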

Compound 4, half-maximal cytotoxic concentration: 29300 nM
Compound 4: middle estimate off by 1.2-fold (0.07 log units), on the low side, within the range that was stated.
By their numbers in this assay, from the lowest: compounds 3, 1 and 4 (each within the scatter of the next, the first and the last beyond it); then compound 2.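

In this assay, for the compounds shown here, fluoro in place of hydrogen on an aromatic carbon, ortho to a large group, gives a 1.1-fold higher number from compound 1 to compound 4 (0.06 log units; within the scatter) and provides the first single-change reading. At this position, on the background of compound 1, phenyl and 2-fluorophenyl cannot be told apart on this read-out. No supporting measurement is available to explain this result.

This single pair does not show whether the same reading would hold at other carbons of that ring, or with the backgrounds of compound 2 and compound 3. Going by these compounds, how an amine or a carboxylic acid would read at this same carbon also remains open, so one fluoro step cannot yet define the tolerance of this position.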